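Alkoxy chain variation in the phenylcyclopropane hydrazide series

This account rests on a few compounds, and the source may have more. Where it says the series, first, only, none or still open, it means among the compounds named here.

Compound 1, `COc1ccc(C2CC2C(=O)NNc2nncc3ccccc23)cc1`: in a functional assay on U-373MG ATCC cells (Homo sapiens) for inhibition, read by MTT assay, with a stated time of 72 h (on this read-out lower numbers stand for stronger inhibition and higher numbers for weaker inhibition), compound 1 gives 83000 nM.
Compound 2, `O=C(NNc1nncc2ccccc12)C1CC1c1ccc(OCC(F)(F)F)cc1`: in this assay compound 2 gives 25000 nM.
Compound 3, `CCOc1ccc(C2CC2C(=O)NNc2nncc3ccccc23)cc1`: in this assay compound 3 gives 91000 nM.

Compound 3 carries the highest number of the three. Its gap to compound 1 is small: a 1.1-fold higher number from compound 1 to compound 3 (0.04 log units; within the scatter). The gap to compound 2 is larger: a 3.6-fold higher number from compound 2 to compound 3 (0.56 log units; beyond the scatter). Within the data shown here, the remaining comparison, a 3.3-fold lower number from compound 1 to compound 2 (0.52 log units; beyond the scatter), is the only step in the set that moved the number beyond the scatter, and it too concerns the group on the saturated chain carbon bound to an oxygen on the aromatic ring.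

Compound 4, `CC(C)=CCOc1ccc(C2CC2C(=O)NNc2nncc3ccccc23)cc1`, alters the same position: 2-methylprop-1-en-1-yl in place of methyl on a saturated chain carbon bound to an oxygen on an aromatic ring. Among the measured compounds shown here, no measured step covers a chain of this kind at that place. For the measured compounds named here, the one change there that moved the number exchanged hydrogen for trifluoromethyl, while adding a methyl left the number where it was, so the measured steps give no direction for a longer chain. The step to compound 4 is therefore expected to be small, a 1.5-fold lower number from compound 3 to compound 4 (0.18 log units; within the scatter), and the direction is uncertain. For compound 4 in this assay the estimate is 60000 nM, with a range from 20000 nM to 150000 nM.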

Compound 4, half-maximal inhibitory concentration: 81000 nM
Compound 4: middle estimate off by 1.4-fold (0.13 log units), on the low side, within the range that was stated.
By their numbers in this assay, from the lowest: compound 2; then compounds 4, 1 and 3 (each within the scatter of the next).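

In this assay, the 2-methylprop-1-en-1-yl group of compound 4 leaves the number within the scatter of both methyl (a 1.1-fold lower number from compound 3 to compound 4 (0.05 log units; within the scatter)) and hydrogen (a 1.0-fold lower number from compound 1 to compound 4 (0.01 log units; within the scatter)), so compounds 1, 3 and 4 now form a single group despite the much longer chain and the added double bond. Compound 2 stands apart from this longer chain as well (a 3.2-fold higher number from compound 2 to compound 4 (0.51 log units; beyond the scatter)), so among these compounds, chain length alone does not account for the separation at the saturated chain carbon bound to an oxygen on an aromatic ring, and trifluoromethyl remains the only group here that moves the number beyond the scatter. Nothing available explains why trifluoromethyl stands apart.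

Still open, from the compounds shown here alone, is whether that separation is specific to trifluoromethyl or extends to difluoromethyl or pentafluoroethyl at this place. The compounds shown also leave open whether 2-methylpropyl, a saturated chain without the double bond, would behave like 2-methylprop-1-en-1-yl, and whether an amine or a carboxylic acid carried on the chain would move the number.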